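Hydrazide aryl variation on the shared core

A few compounds are considered here, and "the series" means these few. Any claim that something is new, unique, unknown or untested is made for them only; others in the source may bear on it.

Compound 3 `CCNC(=O)[C@H]1O[C@@H](n2cnc3c(NNC(=O)c4sccc4C)nc(Cl)nc32)[C@H](O)[C@@H]1O` gives 340 nM in a functional assay on CHO cells for activation of adenosine receptor A2b (Homo sapiens), read by cAMP accumulation; a higher number here means that more compound is needed for the effect, a lower number that less compound is needed. Compound 2 `CCNC(=O)[C@H]1O[C@@H](n2cnc3c(NNC(=O)c4ccc(C)o4)ncnc32)[C@H](O)[C@@H]1O` gives 227 nM in this assay. Compound 1 `CCNC(=O)[C@H]1O[C@@H](n2cnc3c(NNC(=O)c4ccc(Cl)cc4)ncnc32)[C@H](O)[C@@H]1O` reaches only the limit of > 5000 nM in this assay. Compound 3 thus holds the highest of the two numbers, with compound 2 within the scatter of it. Compound 4 `CCNC(=O)[C@H]1O[C@@H](n2cnc3c(NNC(=O)c4cc(-c5ccccc5)on4)nc(Cl)nc32)[C@H](O)[C@@H]1O` carries 5-phenyl-1,2-oxazol-3-yl in place of 3-methylthiophen-2-yl on a carbonyl carbon. Going by the values given here, the only measured step at the carbonyl carbon, an at least 22-fold lower number from compound 1 to compound 2 (1.34 log units; beyond the scatter), shows that this group can shift the number strongly. Compound 1 sits at the limit of > 5000 nM in this assay, at which 1 of the 3 values shown sits, with 4-chlorophenyl there. Compound 4 brings a larger group with two rings in place of one, so a moderately higher number is expected, a step of a 2.1-fold higher number from compound 3 to compound 4 (0.31 log units; beyond the scatter). Compound 4 is estimated at 700 nM, between 150 nM and 3500 nM.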

Compound 4, half-maximal effective concentration: > 5000 nM
Compound 4: only a limit was reported; the forecaster's own chance of this, stated with the estimate: 25%; middle value at least 7.1-fold (0.85 log units) away from the limit.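

On the core of compound 3, 5-phenyl-1,2-oxazol-3-yl in place of 3-methylthiophen-2-yl on the carbonyl carbon gives an at least 14-fold higher number from compound 3 to compound 4 (1.16 log units; beyond the scatter) in this assay, so this position also shifts the number strongly on a second core. In both steps at this position, the compound carrying a six-membered aromatic ring of carbon only is the one at the limit. Compound 4 gives only a limit, not a number, and joins compound 1 there: the limit of > 5000 nM in this assay, at which 2 of the 4 values shown sit.

The compounds shown do not separate the effect of the added phenyl ring from that of replacing the thiophene with the 1,2-oxazole. Going by these compounds, how a 5-methyl-1,2-oxazol-3-yl group would behave on the carbonyl carbon stays open.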